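Benzyl changes on the piperazine series: cytotoxicity notes

This account rests on a few compounds, and the source may have more. Where it says the series, first, only, none or still open, it means among the compounds named here.

In an ADME assay on MT4 cells (Homo sapiens) for cytotoxicity, read by MTT assay, with a stated time of 4 days (on this read-out lower numbers stand for higher toxicity in this test and higher numbers for lower toxicity in this test), the measured compounds read as follows:
compound 1 (`CCOC(=O)c1cnc(N2CCN(Cc3ccc(C#N)cc3)CC2)nc1Oc1c(C)cc(-c2ccc(C#N)cc2)cc1C`): > 125000 nM (a limit)
compound 2 (`CCOC(=O)c1cnc(N2CCN(Cc3cccc(C#N)c3)CC2)nc1Oc1c(C)cc(-c2ccc(C#N)cc2)cc1C`): > 125000 nM (a limit)
compound 3 (`CCOC(=O)c1cnc(N2CCN(Cc3ccc(C(F)(F)F)cc3)CC2)nc1Oc1c(C)cc(-c2ccc(C#N)cc2)cc1C`): > 125000 nM (a limit)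

Compound 3 stands at > 125000 nM and this is a limit, not a number. Among the compounds with values here, the series so far shows only this (the limit of > 125000 nM in this assay, at which 3 of the 3 values shown sit). Compound 4 (`CCOC(=O)c1cnc(N2CCN(Cc3cccc(F)c3)CC2)nc1Oc1c(C)cc(-c2ccc(C#N)cc2)cc1C`) differs from compound 3 by one change (3-fluorophenyl in place of 4-(trifluoromethyl)phenyl on a saturated chain carbon bound to an amine nitrogen in a ring) on the benzyl group. Within the data shown here, three measured steps bear on this place: a step that the two limits leave unreadable from compound 1 to compound 2 and a step that the two limits leave unreadable from compound 1 to compound 3 and also a step that the two limits leave unreadable from compound 2 to compound 3 give no readable size. With no size to carry over, no step beyond the scatter is expected in this assay here. The expected step is a number no higher from compound 3 to compound 4 (the limit leaves the size open) as an estimate only. For compound 4 the estimated value is 125000 nM with an expected range of 50000 nM to 250000 nM and a reading at the same limit is likely.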

Compound 4, half-maximal cytotoxic concentration: > 125000 nM
Compound 4: a limit, no number; the forecaster's own chance of this, stated with the estimate: 80%; the middle value sits exactly at the limit.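

No step can be read between compound 4 and compound 1, compound 2 or compound 3 in this assay, all four values being limits: the limit of > 125000 nM in this assay, at which 4 of the 4 values shown sit.

The compounds shown leave open whether any of these benzyl changes alters cytotoxicity.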